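Adding a Second Methoxy to a Weakly Toxic Chalcone

The source may hold more compounds than are shown below. What is called first, only, known or untested is meant among the compounds shown, and "the series" means these compounds.

Compound 1 `COc1ccc(-c2cc(/C=C/C(=O)c3ccc(N)cc3)[nH]n2)cc1` was tested in a functional assay on SF-268 cells (Homo sapiens) for inhibition, read by sulforhodamine B assay, with a stated time of 48 h (on this read-out higher numbers stand for lower toxicity in this test and lower numbers for higher toxicity in this test), where compound 1 gives 45700 nM. Among the two compounds with data, compound 1 is the only one with a measured number; the other value sits at the limit of > 100000 nM in this assay, at which 1 of the 2 values shown sits. Compound 2 `COc1ccc(C(=O)/C=C/c2cc(-c3cc(OC)c(OC)c(OC)c3)n[nH]2)cc1` in this assay reaches only > 100000 nM, which is a limit of the test rather than a number. Within the data shown here, no pair of measured compounds here differs in a single place, so no step size has yet been seen.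

Compound 3 `COc1ccc(-c2cc(/C=C/C(=O)c3ccc(N)cc3)[nH]n2)cc1OC` differs from compound 1 by methoxy in place of hydrogen on an aromatic carbon. With nothing measured to guide the direction, the step of a 1.1-fold higher number from compound 1 to compound 3 (0.04 log units; within the scatter) is expected to stay within the usual scatter rather than move the toxicity clearly either way. Compound 3 is therefore estimated to give about 50000 nM in this assay, within a range from 20000 nM to 100000 nM.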

Compound 3, concentration lethal to 50% of the cells: 11200 nM
Beside the measured number, compound 3's estimate is 4.5-fold (0.65 log units) above it, outside the stated range (below it).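

Among these compounds, the methoxy in place of hydrogen gives a 4.1-fold lower number from compound 1 to compound 3 (0.61 log units; beyond the scatter) in this assay, and this is the first step seen here, pointing toward higher toxicity in this test. It shows that this aromatic carbon, ortho to a methoxy group and meta to a large group, is not a silent place: a group of just 2 heavy atoms moves the read-out beyond the usual scatter. Nothing measured here explains why the number falls.

The compounds shown leave open whether this shift belongs to methoxy in particular or would also appear with a hydroxyl group, a fluorine atom or a longer chain such as ethoxy on the same carbon. They also leave open whether the same change would act alike in other cell lines.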